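Chloro for Methoxy on a Hydrazone Benzamide

The compounds below may be only part of what the source reports. "The series", "measured", "known", "first", "only" and "open" are said of these compounds alone.

The series is read in a functional assay on cells (Splenocyte, Mus musculus, strain BALB/c) for inhibition, read by scintillation counting and thymidine incorporation, with a stated time of 72 h; on this read-out lower numbers stand for stronger inhibition and higher numbers for weaker inhibition. Compound 1 `CC(/C=N/N(C)c1ccc([N+](=O)[O-])cc1)=N\NC(=O)c1ccccc1O` gives 3120 nM in this assay, and compound 2 `CC(/C=N/N(C)c1ccc([N+](=O)[O-])cc1)=N\NC(=O)c1cc([N+](=O)[O-])cc([N+](=O)[O-])c1` gives 1110 nM. Compound 3 `COc1ccc(C(=O)N/N=C(C)/C=N/Nc2ccc([N+](=O)[O-])cc2)cc1` carries no methyl on the hydrazone nitrogen and a methoxy on its benzamide ring. In this assay compound 3 gives > 12000 nM, which is a limit of the assay and not a number. Compound 3 is therefore the one value that sits at the limit of > 12000 nM in this assay, at which 1 of the 3 values shown sits, and on the numbers shown it stands apart from compound 1 and compound 2, which both return measured values.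

Compound 4 `CC(/C=N/Nc1ccc([N+](=O)[O-])cc1)=N\NC(=O)c1ccc(Cl)cc1` is yet to be measured. It differs from compound 3 in one place: chloro in place of methoxy on an aromatic carbon. Among the compounds with values here, because compound 3 gives only > 12000 nM, the step from it cannot be read from any measured pair, and no step of the same kind is measured elsewhere in the set. The expectation for this assay is a modest move toward lower numbers, with a fair chance that the outcome stays at the limit, and the expected step is an at least 1.5-fold lower number from compound 3 to compound 4 (0.17 log units; that floor lies within the scatter). Compound 4 is estimated at 8000 nM, within a range from 2500 nM to 30000 nM.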

Compound 4, half-maximal inhibitory concentration: 4200 nM
Beside the measured number, compound 4's estimate is 1.9-fold (0.28 log units) above it; the measured number falls inside the stated range.
By their numbers in this assay, from the lowest: compound 2; then compounds 1 and 4 (each within the scatter of the next). At a limit, above all of these: compound 3.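

In this assay the change from methoxy to chloro, on an aromatic carbon para to a large group, gives an at least 2.8-fold lower number from compound 3 to compound 4 (0.45 log units; beyond the scatter). Within the data shown here, this is the first reading at this position: with a chloro there, compound 4 returns a measured value, so a single change at this one place is enough to bring the series off the limit. Compound 3 remains a limit of the assay and not a number, and it is the only such compound: the limit of > 12000 nM in this assay, at which 1 of the 4 values shown sits.

The compounds shown leave open how far the read-out would move with an amine, a carboxylic acid or a longer chain at this same place, and the full size of the step from methoxy to chloro stays unknown, with only its lower bound printed. They also leave open whether chloro in place of methoxy would give a similar step on a compound that carries the methyl on the hydrazone nitrogen, as compound 1 and compound 2 do.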